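The source may report more compounds than this note shows. Statements on the series, on what has been measured and on what is new or still open speak of the compounds shown alone.

Measured compounds:
compound 1, `Nc1nn(C(=O)Nc2ccc(Cc3ccccc3)cc2)c2ccccc12`, with "not determined" (no result reported)
compound 2, `Nc1nn(C(=O)Nc2ccc(Cc3ccccc3)cc2)c2ccc(Cl)cc12`, with > 100000 nM

The two compounds share one core and differ at a single ring position. In a functional assay on CCRF-CEM cells (Homo sapiens) for antiproliferative activity, read by sulforhodamine B assay, with a stated time of 48 h (a lower number here means that less compound is tolerated, a higher number that more compound is tolerated), compound 1 has no reported result, so it gives "not determined" (no result reported). In this assay compound 2 gives > 100000 nM, and this is a limit of the assay rather than a measured number. Compound 2 thus stands at the very edge of what the numbers show: of the two entries, one is a limit and the other carries no number at all, so the only fixed point is the limit of > 100000 nM in this assay, at which 1 of the 2 values shown sits.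

The next compound, compound 3, `Nc1ccc2c(c1)c(N)nn2C(=O)Nc1ccc(Cc2ccccc2)cc1`, has not been measured. It differs from compound 2 by amino in place of chloro on an aromatic carbon. Going by the values given here, no step between measured compounds shows what such a swap does in this assay, so neither direction nor size can be read from data. Because compound 2 gives > 100000 nM, a limit, the expectation is a step of a number no higher from compound 2 to compound 3 (the limit leaves the size open) no larger than the scatter. Compound 3 is therefore estimated at 100000 nM, within a range from 20000 nM to 300000 nM.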

Compound 3, concentration lethal to 50% of the cells: > 100000 nM
Compound 3 ended at the assay's limit; the forecaster's own chance of this, stated with the estimate: 80%; the middle value lies on the limit itself.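

Compound 2 and compound 3 both end at a limit of the assay rather than at a number, so no step can be read between them, because both sit at the same boundary: the limit of > 100000 nM in this assay, at which 2 of the 3 values shown sit.

The compounds shown leave open whether amino in place of chloro on an aromatic carbon shifts the result at all in this assay, and in which direction.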